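This account rests on a few compounds, and the source may have more. Where it says the series, first, only, none or still open, it means among the compounds named here.

Working notes on the series. All three measured compounds share the core of compound 1 `CCC1(Cc2ccccc2)OS(=O)(=O)C=C1OCc1ccc(Cl)c(Cl)c1` and differ only at the oxygen on the unsaturated carbon. In an ADME assay on HEL cells (Homo sapiens) for cytotoxicity, with a stated time of 3 days (on this read-out higher numbers stand for lower toxicity in this test and lower numbers for higher toxicity in this test), compound 1 gives >= 20000 nM, which is a limit of the assay. Compound 2 `CCC1(Cc2ccccc2)OS(=O)(=O)C=C1OC(=O)c1ccccc1` gives > 400000 nM in this assay, also a limit. Compound 3 `CCC1(Cc2ccccc2)OS(=O)(=O)C=C1OCCCCc1ccccc1` gives >= 20000 nM in this assay, again a limit. The step that the two limits leave unreadable from compound 1 to compound 3 can therefore not be sized; the limit of >= 20000 nM in this assay, at which 2 of the 3 values shown sit, and the limit of > 400000 nM in this assay, at which 1 of the 3 values shown sits, are all the numbers offer. Compound 4 `C=CCOC1=CS(=O)(=O)OC1(CC)Cc1ccccc1` differs from compound 3 as follows: vinyl in place of 3-phenylpropyl on a saturated chain carbon bound to an oxygen on an unsaturated carbon. Going by the values given here, no measured step bears on this change, so no step beyond the scatter is expected. In this assay compound 4 is expected at 40000 nM, with a range from 15000 nM to 400000 nM. This means an expected step that the limit leaves unreadable from compound 3 to compound 4.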

Compound 4, minimum cytotoxic concentration: 80000 nM
Beside the measured number, compound 4's estimate is 2.0-fold (0.30 log units) below it; the range from low to high includes it.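

In this assay, going by these compounds alone, compound 4 gives 80000 nM, the only value shown that is a number and not a limit. Allyl in place of benzoyl on the oxygen on the unsaturated carbon gives an at least 5.0-fold lower number from compound 2 to compound 4 (0.69 log units; beyond the scatter), so a change at this position can move the read-out beyond the scatter. The steps to compound 4 from compound 1 and compound 3 cannot be read: the limit of >= 20000 nM in this assay, at which 2 of the 4 values shown sit.

Still open, as far as these compounds go, is how far the number would move with an amine or a carboxylic acid at the end of the chain on this oxygen. A single value also cannot show whether allyl differs from the 3-phenylpropyl or 3,4-dichlorophenyl groups.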